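The source may report more compounds than this note shows. Statements on the series, on what has been measured and on what is new or still open speak of the compounds shown alone.

Measured in a functional assay on A549 cells (Homo sapiens) for antiproliferative activity, read by MTT assay, with a stated time of 72 h; on this read-out lower numbers stand for stronger inhibition and higher numbers for weaker inhibition:
- Compound 1 `NC1=NC2(CCSCC2)N(OCCCOc2ccc(Cl)c(Cl)c2)C(N)=N1`: 1 nM
- Compound 2 `NC1=NC2(CCOCC2)N(OCCCOc2ccccc2)C(N)=N1`: 1080 nM

Compound 2, at 1080 nM, holds the higher of the two numbers in this assay, and its gap to compound 1 lies beyond the scatter. Those two compounds differ in more than one place, so they do not isolate the change at hand. Compound 3 `COc1ccc(OCCCON2C(N)=NC(N)=NC23CCOCC3)cc1` has methoxy in place of hydrogen on an aromatic carbon, para to a large group: methoxy in place of hydrogen on an aromatic carbon. For the measured compounds named here, with no measured step to draw on, only a small move toward lower numbers is expected, perhaps none beyond the scatter, and the expected step is a 1.8-fold lower number from compound 2 to compound 3 (0.26 log units; within the scatter). The estimated value for compound 3 is 600 nM, with an expected range from 150 nM to 2500 nM.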

Compound 3, half-maximal inhibitory concentration: 660 nM
Compound 3: the middle estimate sits 1.1-fold (0.04 log units) below what was measured, and the stated range covers the measured number.
By their numbers in this assay, from the lowest: compound 1; then compounds 3 and 2 (each within the scatter of the next).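

In this assay, for the compounds shown here, methoxy in place of hydrogen on an aromatic carbon, para to a large group, gives a 1.6-fold lower number from compound 2 to compound 3 (0.21 log units; within the scatter) and so provides the first comparison of compounds that differ in one place. At this position, the change from phenyl to 4-methoxyphenyl produces no difference that can be separated from the scatter. Nothing available here gives a measured explanation for this result.

As far as these compounds go, it remains open whether an amine or a carboxylic acid at this position would give a step beyond the scatter. The same question stands for a longer chain, such as butoxy.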